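A Methyl-to-Chloro Change at the Assay Limit

This account rests on a few compounds, and the source may have more. Where it says the series, first, only, none or still open, it means among the compounds named here.

- Compound 1 `Cc1ccccc1-n1nc(-c2ccccc2)nc1CNc1ccc(C(=O)NO)cc1`: 12300 nM
- Compound 2 `Cc1ccc(-c2nc(CNc3ccc(C(=O)NO)cc3)n(-c3ccccc3)n2)cc1`: > 20000 nM
- Compound 3 `COc1ccc(-n2nc(-c3ccc(O)cc3)nc2CNc2ccc(C(=O)NO)cc2)cc1`: > 20000 nM

All three compounds were tested in a functional assay on MGC-803 cells (Homo sapiens) for antiproliferative activity, read by MTT assay, with a stated time of 72 h; a higher number here means a weaker inhibitor, a lower number a stronger inhibitor. Only compound 1 has a measured number here. For compound 2 the entry > 20000 nM is a limit of the assay and not a number. Compound 3 also gives a limit, > 20000 nM. The small set therefore rests largely on (the limit of > 20000 nM in this assay, at which 2 of the 3 values shown sit), and compound 2 stands at that limit with no exact value.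

The next compound to be measured is compound 4 `O=C(NO)c1ccc(NCc2nc(-c3ccc(Cl)cc3)nn2-c2ccccc2)cc1`, which differs from compound 2 in one place: chloro in place of methyl on an aromatic carbon. In words, this is chloro in place of methyl on an aromatic carbon, turning 4-methylphenyl into 4-chlorophenyl.

Within the data shown here, no measured pair in this set shows a change of this kind, so the size of the step cannot be read from the data. No step beyond the usual scatter is expected in this assay, in either direction. The estimated step that the limit leaves unreadable from compound 2 to compound 4 is expected to be small. This expectation rests on compound 2, whose > 20000 nM is a limit, so a limit is also a likely outcome for the next result. For compound 4 the expected value is 22000 nM, with an estimated range from 9000 nM to 50000 nM.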

Compound 4, half-maximal inhibitory concentration: 5970 nM
Compound 4: the middle estimate sits 3.7-fold (0.57 log units) above what was measured; measured number outside the range, below it.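

In this assay compound 2 gives > 20000 nM, which is a limit of the assay and not a number. Chloro in place of methyl on an aromatic carbon, turning 4-methylphenyl into 4-chlorophenyl, gives an at least 3.3-fold lower number from compound 2 to compound 4 (0.52 log units; beyond the scatter), so this place, para to a large group on the six-membered aromatic ring of carbon only, is shown for the first time to respond to a change of a single heavy atom, and compound 4 brings this part of the series down to a measured number. The full size of the step cannot be read, and only its lower bound is known, because the starting point of the pair is a limit: the limit of > 20000 nM in this assay, at which 2 of the 4 values shown sit.

Only methyl and chloro are shown at this place, so it stays open whether a fluoro, a methoxy group or an amine there would give a measured number like compound 4 or a limit like compound 2. Going by these compounds, compound 1 and compound 3 each differ from compound 4 in more than one place, so whether the gain from chloro carries over to other groups on the rest of the core also stays open.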